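This account rests on a few compounds, and the source may have more. Where it says the series, first, only, none or still open, it means among the compounds named here.

Compound 2 `O=c1cc(-c2ccccc2)oc2cc(OCc3ccccc3)c(OCCCN3CCCCC3)c(O)c12` stands lowest of the three numbers in a functional assay on HepG2 cells (Homo sapiens) for antiproliferative activity, read by MTT assay, with a stated time of 48 h (on this read-out lower numbers stand for stronger inhibition and higher numbers for weaker inhibition), giving 2200 nM. Compound 1 `O=c1cc(-c2ccccc2)oc2cc(O)c(OCCCN3CCCCC3)c(O)c12` gives 70600 nM, and compound 3 `COc1cc2oc(-c3ccccc3)cc(=O)c2c(O)c1OCCCN1CCCCC1` gives 22300 nM. The step of a 32-fold lower number from compound 1 to compound 2 (1.51 log units; beyond the scatter) and the step of a 10-fold higher number from compound 2 to compound 3 (1.01 log units; beyond the scatter) both turn on the benzyl on an oxygen on an aromatic ring, and a 3.2-fold lower number from compound 1 to compound 3 (0.50 log units; beyond the scatter) on a methyl at the same kind of oxygen. Compound 4 `CN(C)CCCOc1c(OCc2ccccc2)cc2oc(-c3ccccc3)cc(=O)c2c1O` differs from compound 2 by dimethylamino in place of piperidin-1-yl on a saturated chain carbon, three bonds along the chain from an oxygen on an aromatic ring. Within the data shown here, none of the measured steps touches the amine at the end of the propyl chain, so they bear only indirectly on this change, and the step from compound 2 to compound 4 in this assay is expected to be small, a 1.2-fold higher number from compound 2 to compound 4 (0.07 log units; within the scatter), within the scatter. Compound 4 is estimated at 2600 nM, with a range from 900 nM to 8000 nM.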

Compound 4, half-maximal inhibitory concentration: 2200 nM
For compound 4 the middle estimate is 1.2-fold (0.07 log units) above the measured one; measured number inside the range.
By their numbers in this assay, from the lowest: compounds 2 and 4 (each within the scatter of the next); then compound 3; then compound 1.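

Among these compounds, the earlier compounds differ only on the oxygens of the core, whereas this step is the first reading at the amine end of the chain. In this assay, dimethylamino in place of piperidin-1-yl gives no change at the digits printed from compound 2 to compound 4 (within the scatter), so with benzyl on the oxygen, the piperidine ring is not needed to hold this number. No evidence at hand bears on why the two amines read alike.

As far as these compounds go, whether morpholin-4-yl or diethylamino at the chain end would read the same stays open. So does whether the same amine change would read alike with methyl or hydrogen in place of benzyl.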